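The compounds below may be only part of what the source reports. "The series", "measured", "known", "first", "only" and "open" are said of these compounds alone.

Measured compounds:
- compound 1, `Cc1nc(N)sc1CCCNC(=N)NC(=O)C[C@@H](C)c1ccccc1`, gives 17 nM in an in vitro functional assay on Sf9 cells for agonist activity at histamine H2 receptor (Cavia porcellus), read by GTPgammaS binding; a lower number here means that less compound is needed, a higher number that more compound is needed for the effect
- compound 2, `Cc1nc(N)sc1CCCNC(=N)NC(=O)C[C@H](C)C1CCCCC1`, gives 14.1 nM in this assay
- compound 3, `Cc1nc(N)sc1CCCNC(=N)NC(=O)CC(C)c1ccccc1`, gives 22.4 nM in this assay

Compound 1 holds the second highest number of the three. Its closest neighbour is compound 2, with a 1.2-fold lower number from compound 1 to compound 2 (0.08 log units; within the scatter), and the gap to compound 3 is a 1.3-fold higher number from compound 1 to compound 3 (0.12 log units; within the scatter); both lie within the scatter of repeated measurements, so the three compounds cannot be ranked against each other.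

Compound 4 is `Cc1nc(N)sc1CCCNC(=N)NC(=O)C[C@H](C)c1ccccc1`. It differs from compound 1 only in the drawn configuration of one stereocentre: the two compounds have the same atoms and bonds; at least one stereo element is drawn with a configuration in one of them and without one in the other: 1 of 2 stereo elements differ; a stereocentre at a saturated chain carbon is drawn R in compound 1 and S in compound 4.

Among the compounds with values here, the one measured step that bears on this is the step from compound 1 to compound 3, a 1.3-fold higher number from compound 1 to compound 3 (0.12 log units; within the scatter), since it is the fact that one of compounds 1 and 3 is drawn with a defined configuration and the other without, at the place where they differ that separates those two. That step was small and within the scatter. Changing the drawn configuration from R to S is therefore expected to move the number little, perhaps slightly upward, and the step from compound 1 to compound 4 is estimated at a 1.8-fold higher number from compound 1 to compound 4 (0.25 log units; within the scatter). Compound 4 is expected to give 30 nM, within a range from 12 nM to 80 nM.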

Compound 4, half-maximal effective concentration: 7.76 nM
Beside the measured number, compound 4's estimate is 3.9-fold (0.59 log units) above it, outside the stated range (below it).
By their numbers in this assay, from the lowest: compounds 4, 2, 1 and 3 (each within the scatter of the next, the first and the last beyond it).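

Within the data shown here, the configuration at this saturated chain carbon does matter in this assay, which the earlier compounds could not show: there is a 2.2-fold lower number from compound 1 to compound 4 (0.34 log units; beyond the scatter), and only one thing separates the pair: the fact that one of compounds 1 and 4 is drawn with a defined configuration and the other without, at the place where they differ. The step from the undefined form is also beyond the scatter, with a 2.9-fold lower number from compound 3 to compound 4 (0.46 log units; beyond the scatter), so the form drawn S stands apart from both the form drawn R and the form drawn without a configuration. Against the cyclohexyl analogue there is a 1.8-fold lower number from compound 2 to compound 4 (0.26 log units; within the scatter), which is within the scatter, so these two compounds cannot be ranked and the change from cyclohexyl to phenyl shows no clear effect here.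

Going by these compounds, whether the same dependence on configuration holds for the cyclohexyl series stays open. So does what would happen if a longer chain or a hydroxyl group replaced the methyl on this carbon.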